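The source may hold more compounds than are shown below. What is called first, only, known or untested is meant among the compounds shown, and "the series" means these compounds.

Measured compounds in an ADME assay on HepG2 2.2.15 cells (Homo sapiens) for cytotoxicity, read by MTT assay, with stated times of 48 h and 9 days; on this read-out higher numbers stand for lower toxicity in this test and lower numbers for higher toxicity in this test:
- compound 1 `COc1ccc2c(=O)c(/C=C/C(=O)Nc3ccc(Cl)cc3)coc2c1`: 272000 nM
- compound 2 `Cc1ccccc1NC(=O)/C=C/c1coc2cc(O)ccc2c1=O`: 374000 nM
- compound 3 `O=C(/C=C/c1coc2cc(O)ccc2c1=O)Nc1ccccc1`: 821000 nM

Compound 1 has the lowest of the three numbers in this assay. Among the measured compounds shown here, its nearest neighbour is compound 2, whose value lies within the scatter of that of compound 1; compound 3 stands furthest, its value being higher by more than the scatter, though no single-point step joins compound 1 and compound 3.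

For the measured compounds named here, the only step between compounds that differ in one place is a 2.2-fold higher number from compound 2 to compound 3 (0.34 log units; beyond the scatter), a modest gain on the read-out. That step concerns a methyl on an aromatic carbon and does not touch the change now in question.

Compound 4 `COc1ccc2c(=O)c(/C=C/C(=O)Nc3ccccc3Cl)coc2c1` is the unmeasured partner of compound 1; the change is 2-chlorophenyl in place of 4-chlorophenyl on an amide-type nitrogen. Going by the values given here, nothing among the measured steps speaks to moving a chlorine within the aryl group on the amide-type nitrogen, so no step beyond the scatter is expected in this assay. The expected step of a 1.0-fold higher number from compound 1 to compound 4 (0.01 log units; within the scatter) is accordingly set close to zero. For compound 4 the estimate is 280000 nM in this assay, with a range from 110000 nM to 700000 nM that allows for the absence of any directly comparable step.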

Compound 4, half-maximal cytotoxic concentration: 1010000 nM
Compound 4: the middle estimate sits 3.6-fold (0.56 log units) below what was measured, and the stated range ends below it.
By their numbers in this assay, from the lowest: compounds 1 and 2 (each within the scatter of the next); then compounds 3 and 4 (each within the scatter of the next).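

In this assay, moving the chlorine within the aryl group on the amide-type nitrogen is not a neutral exchange: a 3.7-fold higher number from compound 1 to compound 4 (0.57 log units; beyond the scatter), a modest step, although the two groups match in heavy atoms, hydrogen-bond donors, hydrogen-bond acceptors and charge. This position therefore responds to where the chlorine sits on the aryl group and not only to which atoms are present, which the earlier methyl-to-hydrogen step could not show. Nothing available here accounts for this step.

As far as these compounds go, it remains open whether moving the chlorine has a similar effect on the core of compound 3, whose aryl group carries no chlorine. Also open, from the compounds shown here alone, is how this position would respond to an amine or a carboxylic acid in place of the chlorine.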